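Side-chain exchange on the shared core: next estimate

The source may report more compounds than this note shows. Statements on the series, on what has been measured and on what is new or still open speak of the compounds shown alone.

In a functional assay on DU-145 cells (Homo sapiens) for cytotoxicity, read by MTT assay (on this read-out higher numbers stand for weaker inhibition and lower numbers for stronger inhibition), compound 3 `CCC(CO[C@H](CC=C(C)C)C1=CC(=O)c2c(O)ccc(O)c2C1=O)OC(C)=O` gives 25400 nM and compound 1 `CC(=O)OCCC(=O)O[C@H](CC=C(C)C)C1=CC(=O)c2c(O)ccc(O)c2C1=O` gives 15700 nM, the two lying within the scatter of each other. Compound 2 `CCCC(CC(=O)O[C@H](CC=C(C)C)C1=CC(=O)c2c(O)ccc(O)c2C1=O)OC(C)=O` gives 55700 nM, a higher number than either, beyond the scatter of both.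

Next in the series is compound 4 `CC(C)=CC[C@@H](OC(=O)C1CCCCO1)C1=CC(=O)c2c(O)ccc(O)c2C1=O`. The change is (oxan-2-yl)carbonyl in place of 2-acetoxybutyl on an oxygen on a saturated carbon.

For the measured compounds named here, two measured steps bear on this. The exchange of (2-acetoxyethyl)carbonyl for 2-acetoxybutyl on the same oxygen gives a 1.6-fold higher number from compound 1 to compound 3 (0.21 log units; within the scatter), so that exchange did not move the number beyond the scatter. Propyl in place of hydrogen on the chain gives a 3.5-fold higher number from compound 1 to compound 2 (0.55 log units; beyond the scatter), which shows that a chain change in a carbonyl-bearing compound can produce a modest step. Going by the values given here, no measured compound carries the oxan-2-yl ring, so the data cannot show what the ring itself does. Compound 1 and compound 2 both carry a carbonyl on that oxygen, and compound 3 falls within their span.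

The expected change is a 1.0-fold higher number from compound 3 to compound 4 (0.01 log units; within the scatter), which means no step beyond the scatter is anticipated in either direction. The estimate in this assay for compound 4 is 26000 nM, with an expected range of 10000 nM to 60000 nM.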

Compound 4, half-maximal inhibitory concentration: 24700 nM
Estimate against measurement, compound 4: 1.1-fold (0.02 log units) above, within the range that was stated.
By their numbers in this assay, from the lowest: compounds 1, 4 and 3 (each within the scatter of the next); then compound 2.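

In this assay, (oxan-2-yl)carbonyl in place of 2-acetoxybutyl on the oxygen gives a 1.0-fold lower number from compound 3 to compound 4 (0.01 log units; within the scatter), and oxan-2-yl in place of 2-acetoxyethyl on the carbonyl carbon gives a 1.6-fold higher number from compound 1 to compound 4 (0.20 log units; within the scatter). For the compounds shown here, a six-membered non-aromatic ring can therefore stand at this position without a step beyond the scatter from either of these open-chain side chains, which the earlier compounds, all without a ring there, could not show. Oxan-2-yl in place of 2-acetoxypentyl gives a 2.3-fold lower number from compound 2 to compound 4 (0.35 log units; beyond the scatter), so among the four compounds only the side chain of compound 2 stands apart, and no available measurement accounts for any of these steps.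

Open, as far as these compounds go, is whether the ring oxygen of oxan-2-yl matters at all: a cyclohexyl group or a piperidin-2-yl group, with its ring amine, on the same carbonyl carbon would test this. Also open, from the compounds shown here alone, is whether any side chain here, such as one ending in a free carboxylic acid or a longer chain than 2-acetoxypentyl, moves the number well away from the span of these four compounds.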